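A few compounds are considered here, and "the series" means these few. Any claim that something is new, unique, unknown or untested is made for them only; others in the source may bear on it.

Compound 1, `CNC(=O)CCn1nc(-c2ccccc2)ccc1=O`, is the reference point. For the measured compounds named here, in a functional assay on the whole organism (stomach) for inhibition, with Rattus norvegicus as the target, at a dose of 100 mg/kg by the intraduodenal route (on this read-out higher numbers stand for more inhibition at the one dose given (going by the name of the read-out) and lower numbers for less inhibition), compound 1 gives 3.5%, the lowest of the three numbers so far; the nearest is compound 2, `N=C(S)CCn1nc(-c2ccc(Cl)c(Cl)c2)ccc1=O`, which gives 55.8%, and the furthest is compound 3, `N=C(S)CCn1ncc2ccccc2c1=O`, which gives 58.3%, both standing beyond the scatter above compound 1. Compound 4, `CN(C)C(=S)CCn1nc(-c2ccccc2)ccc1=O`, has not been measured. It differs from compound 1 by a group of 5 heavy atoms (3 carbon, 1 nitrogen, 1 sulfur; no ring) in place of a group of 4 heavy atoms (2 carbon, 1 nitrogen, 1 oxygen; no ring), on a saturated chain carbon, two bonds along the chain from an aromatic nitrogen. Going by the values given here, no measured pair shows this exchange, so its size is not known from the data. Both compound 2, with 55.8%, and compound 3, with 58.3%, carry the sulfur. On that basis a rise of a number 31.5 percentage points higher from compound 1 to compound 4 (beyond the scatter) is expected, beyond the scatter. Compound 4 is estimated at 35%, with a range from 10% to 65%.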

Compound 4, a percentage reported as inhibition, in the whole organism at one dose (the size of the read-out at that dose, not a potency): 46%
Compound 4: the middle estimate sits 11 percentage points below what was measured, within the range that was stated.
By their numbers in this assay, from the lowest: compound 1; then compounds 4, 2 and 3 (each within the scatter of the next, the first and the last beyond it).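

The large step of a number 42.5 percentage points higher from compound 1 to compound 4 (beyond the scatter) in this assay shows that inhibition at this position on the saturated chain responds strongly to the exchange, with the rest of the structure unchanged. The exchange puts sulfur in place of oxygen, adds a carbon and removes the hydrogen-bond donor, and this single step cannot separate these changes. No measurement here explains the size of the step.

From the compounds shown here alone, it remains open whether the dimethylamide, with oxygen kept, or the N-methyl thioamide would match this level. A carboxylic acid or a longer chain at this position also remains untested in the compounds shown.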